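A few compounds are considered here, and "the series" means these few. Any claim that something is new, unique, unknown or untested is made for them only; others in the source may bear on it.

Measured compounds:

Compound 1 `COc1cc(-c2nn(-c3cccc(NC(=O)Nc4cc(C(F)(F)F)cc(C(F)(F)F)c4)c3)cc2-c2ccncc2)ccc1Cl`, which in a functional assay on SK-OV-3 cells (Homo sapiens) for inhibition, read by sulforhodamine B assay, with a stated time of 48 h (on this read-out lower numbers stand for stronger inhibition of growth and higher numbers for weaker inhibition of growth), gives 1090 nM.
Compound 2 `COc1cc(-c2nn(-c3cccc(NC(=O)Nc4ccc(Cl)c(Cl)c4)c3)cc2-c2ccncc2)ccc1Cl`, which in this assay gives 1930 nM.

Compound 2 has the highest of the two numbers shown, yet its nearest neighbour, compound 1, stands within the scatter of it, so the two values show no difference that can be read as real. Both carry the same core and a urea link; they differ only in the aryl group on the far side of that urea.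

Compound 3 `COc1cc(-c2nn(-c3cccc(NC(=O)Nc4cccc(C(F)(F)F)c4)c3)cc2-c2ccncc2)ccc1Cl` follows from compound 2 by the change (3-(trifluoromethyl)phenyl in place of 3,4-dichlorophenyl on an amide-type nitrogen). Nothing measured here bridges exactly this exchange, so the size of the step can only be guessed from the two values given. Those two values sit close together despite different substitution of that aryl ring, which suggests the read-out is not very sensitive to this part of the molecule. Compound 3 is therefore expected to give roughly the same number as its neighbours, with a step of a 1.0-fold higher number from compound 2 to compound 3 (0.02 log units; within the scatter) that is estimated to lie within the scatter, in either direction. The estimate for compound 3 is 2000 nM, with a range from 700 nM to 6000 nM.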

Compound 3, concentration for 50% growth inhibition: 2020 nM
Compound 3: middle estimate off by 1.0-fold (0.00 log units), on the low side, within the range that was stated.
By their numbers in this assay, from the lowest: compounds 1, 2 and 3 (each within the scatter of the next).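

In this assay, 3-(trifluoromethyl)phenyl in place of 3,4-dichlorophenyl on the amide-type nitrogen gives a 1.0-fold higher number from compound 2 to compound 3 (0.02 log units; within the scatter), so this exchange of one substituted aryl group for another leaves no difference that can be read as real. Hydrogen in place of one trifluoromethyl on an aromatic carbon gives a 1.9-fold higher number from compound 1 to compound 3 (0.27 log units; within the scatter), which adds a comparison in which only a single group on that ring differs, and this step also stays within the scatter, so all three aryl groups tried at this place fall within the scatter of the next in the series. No measurement is available that would explain why these values stay so close together.

The compounds shown leave open whether any group at this place can move the number beyond the scatter, since all three aryl rings carry only chlorine or trifluoromethyl. A carboxylic acid or a morpholine on that ring, or a benzyl group in place of the aryl group on the amide-type nitrogen, would reach beyond what these three values can say, and so would a change to the shared core.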